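The compounds below may be only part of what the source reports. "The series", "measured", "known", "first", "only" and "open" are said of these compounds alone.

Compound 1, `ClCc1ccc(Cn2cnc3c(Cl)ncnc32)cc1`, gives 1380 nM in a functional assay on A549 cells (Homo sapiens) for cytotoxicity, read by sulforhodamine B assay, with a stated time of 48 h; on this read-out lower numbers stand for stronger inhibition of growth and higher numbers for weaker inhibition of growth.
Compound 2, `ClCc1ccccc1Cn1cnc2c(Cl)nc(Cl)nc21`, gives 2230 nM in this assay.
Compound 3, `Nc1nc(Cl)c2ncn(Cc3ccc(CCl)cc3)c2n1`, gives 15900 nM in this assay.

Among these three numbers compound 2 holds the second highest. Its nearest neighbour is compound 1, whose value lies within the scatter of that of compound 2, so the two cannot be told apart. Going by the values given here, compound 3 stands well away from both, and the single step that joins two of the measured compounds, a 12-fold higher number from compound 1 to compound 3 (1.06 log units; beyond the scatter), is large; it concerns an amino group entering the shared core, and has no bearing on the change considered here.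

Compound 4, `ClCc1ccccc1Cn1cnc2c(Cl)ncnc21`, differs from compound 2 by hydrogen in place of chloro on an aromatic carbon. Among the compounds with values here, no measured pair isolates this change. Compound 1 and compound 2 differ in two places, one of them being this same chloro group, and their values lie within the scatter of one another, which is the only hint available. On that basis the step of a 1.2-fold lower number from compound 2 to compound 4 (0.09 log units; within the scatter) is expected to stay within the scatter, in no clear direction. Compound 4 is therefore estimated at 1800 nM in this assay, with a range from 700 nM to 4500 nM.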

Compound 4, concentration for 50% growth inhibition: 7760 nM
Estimate against measurement, compound 4: 4.3-fold (0.63 log units) below; the measured number lies above the stated range.
By their numbers in this assay, from the lowest: compounds 1 and 2 (each within the scatter of the next); then compound 4; then compound 3.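

Going by these compounds alone, the chloro group between two ring nitrogen atoms counts: in this assay, replacing it with hydrogen gives a 3.5-fold higher number from compound 2 to compound 4 (0.54 log units; beyond the scatter), so growth inhibition weakens, an effect that no single-place comparison among the earlier compounds could show. This is the same place on the shared core where the earlier step, a 12-fold higher number from compound 1 to compound 3 (1.06 log units; beyond the scatter), put amino in place of hydrogen, so changes here have now moved the number beyond the scatter in both available pairs, although those pairs carry different benzyl substituents and the size of the two steps cannot be set against each other as a like-for-like comparison. Nothing available explains why the number rises when the chloro group leaves.

On these data alone, only chloro, hydrogen and amino are seen at this place, so it remains open how fluoro, methyl or methoxy there would compare, and whether any of them would match the chloro group of compound 2. As far as these compounds go, it also remains open whether the chloro-to-hydrogen step has a similar size when the chloromethyl group stands as in compound 1.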